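Moving the Methoxy Group on an N-Methylated Amide

A few compounds are considered here, and "the series" means these few. Any claim that something is new, unique, unknown or untested is made for them only; others in the source may bear on it.

Compound 1 `COc1ccc(-c2cccc(C(=O)N(C)C)c2)cc1S(=O)(=O)Nc1ccc2cccc(NC(=O)c3ccccc3)c2c1`: 873 nM
Compound 2 `COc1cccc(C(=O)Nc2cccc3ccc(NS(=O)(=O)c4cc(-c5cccc(C(=O)N(C)C)c5)ccc4OC)cc23)c1`: 24.3 nM
Compound 3 `COc1ccccc1C(=O)N(C)c1cccc2ccc(NS(=O)(=O)c3cc(-c4cccc(C(=O)N(C)C)c4)ccc3OC)cc12`: > 10000 nM (a limit of the assay)

In a functional assay on CHO cells for agonist activity at Orexin receptor type 2 (Homo sapiens) (a lower number here means that less compound is needed, a higher number that more compound is needed for the effect), compound 3 gives only a limit, > 10000 nM, which is the limit of > 10000 nM in this assay, at which 1 of the 3 values shown sits. Compound 3 therefore stands at the weak end of the three. Compound 4 `COc1cccc(C(=O)N(C)c2cccc3ccc(NS(=O)(=O)c4cc(-c5cccc(C(=O)N(C)C)c5)ccc4OC)cc23)c1` differs from it by 3-methoxyphenyl in place of 2-methoxyphenyl on a carbonyl carbon. Among the compounds with values here, two measured steps bear on this change. a 36-fold lower number from compound 1 to compound 2 (1.56 log units; beyond the scatter) shows a large gain when the 3-methoxy group is present. an at least 410-fold higher number from compound 2 to compound 3 (2.61 log units; beyond the scatter) combines moving that methoxy group with methylation of the amide nitrogen, and compound 4 keeps the methyl, so the two parts of that loss cannot be told apart. Compound 4 is expected to improve on compound 3 by an at least 2.5-fold lower number from compound 3 to compound 4 (0.39 log units; beyond the scatter), but not to regain the level of compound 2. The estimate for compound 4 is 4000 nM, ranging from 400 nM to 30000 nM.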

Compound 4, half-maximal effective concentration: 22.7 nM
Compound 4: middle estimate off by 180-fold (2.25 log units), on the high side; the measured number lies below the stated range.
By their numbers in this assay, from the lowest: compounds 4 and 2 (each within the scatter of the next); then compound 1. At a limit, above all of these: compound 3.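

With the amide nitrogen methylated, shifting the methoxy group from 2-methoxyphenyl to 3-methoxyphenyl gives an at least 440-fold lower number from compound 3 to compound 4 (2.64 log units; beyond the scatter), though the value for compound 3 is only a limit of the assay, so the loss in compound 3 tracks the methoxy position and not the methyl. Methyl in place of the amide hydrogen leaves no readable difference, with a 1.1-fold lower number from compound 2 to compound 4 (0.03 log units; within the scatter), so that hydrogen is not required in this assay. The gain over the unsubstituted benzamide also survives methylation, with a 38-fold lower number from compound 1 to compound 4 (1.58 log units; beyond the scatter).

On these data alone, whether an ethyl group on the amide nitrogen, or a hydroxy or dimethylamino group in place of the 3-methoxy, would be tolerated stays open. Also open, as far as these compounds go, is how 2-methoxyphenyl behaves with the amide hydrogen kept.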